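Swapping the Amide Aryl Group: From Chloro to Trifluoromethyl

This account rests on a few compounds, and the source may have more. Where it says the series, first, only, none or still open, it means among the compounds named here.

Compound 1, `COc1cc(-c2cc(C(=O)O)c3ccccc3n2)ccc1OCC(=O)Nc1cccc(C)c1`: 1.5 in a physicochemical assay for lipophilicity, using the shake flask method, in phosphate buffer, measured as octanol-water partition, at pH 7.4; on this read-out higher numbers stand for higher lipophilicity and lower numbers for lower lipophilicity
Compound 2, `COc1cc(-c2cc(C(=O)O)c3ccccc3n2)ccc1OCC(=O)Nc1ccccc1F`: 0.9 in this assay
Compound 3, `COc1cc(-c2cc(C(=O)O)c3ccccc3n2)ccc1OCC(=O)Nc1ccc(Cl)cc1`: 1.5 in this assay

The three measured compounds share one core and differ only in the aryl group attached to the amide nitrogen. In this assay compound 3 stands level with compound 1, and together they sit at the top of the three numbers: the step of no change at the digits printed from compound 1 to compound 3 (within the scatter) is within the scatter of the method. Compound 2 sits clearly lower, as the step of a number 0.60 log units higher from compound 2 to compound 3 (beyond the scatter) shows.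

Compound 4, `COc1cc(-c2cc(C(=O)O)c3ccccc3n2)ccc1OCC(=O)Nc1cccc(C(F)(F)F)c1`, is the next member of the series. It carries 3-(trifluoromethyl)phenyl in place of 4-chlorophenyl on an amide-type nitrogen. Neither group is a hydrogen-bond donor or acceptor, and the change leaves the rest of the molecule untouched.

For the measured compounds named here, no measured step introduces a trifluoromethyl group, so the expectation rests on how much the earlier aryl swaps moved the number: one left it unchanged, no change at the digits printed from compound 1 to compound 3 (within the scatter), the other moved it modestly, a number 0.60 log units higher from compound 2 to compound 3 (beyond the scatter). A small upward step is expected, a number 0.20 log units higher from compound 3 to compound 4 (within the scatter), staying close to compound 3. Compound 4 is therefore estimated at 1.7, with a range from 1.3 to 2.1.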

Compound 4, distribution coefficient: 1.3
Compound 4: the middle estimate sits 0.40 log units above what was measured, within the range that was stated.
By their numbers in this assay, from the lowest: compound 2; then compounds 4, 1 and 3 (each within the scatter of the next).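

On the amide-type nitrogen, replacing 4-chlorophenyl with the larger 3-(trifluoromethyl)phenyl leaves the number in this assay within the scatter, a number 0.20 log units lower from compound 3 to compound 4 (within the scatter), so the top group of values now holds a third aryl group. The comparison with compound 1 adds a narrower test. For the compounds shown here, only one group on the ring differs: trifluoromethyl stands in place of methyl, and the result is a number 0.20 log units lower from compound 1 to compound 4 (within the scatter), again within the scatter. Among these four compounds, 2-fluorophenyl alone stands apart, and the new compound also separates from it, a number 0.40 log units higher from compound 2 to compound 4 (beyond the scatter), while nothing shown explains why the numbers fall this way.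

The compounds shown leave open whether the lower value of compound 2 goes with the fluorine itself or with its place on the ring, a question that 4-fluorophenyl on the same amide-type nitrogen could help to settle. They also leave open how far this position tolerates change before the number moves, since every group here is a substituted phenyl and an aryl group carrying an amine or a carboxylic acid could test a very different kind of substituent.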